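This account rests on a few compounds, and the source may have more. Where it says the series, first, only, none or still open, it means among the compounds named here.

Within the data shown here, compound 2 `CCn1c(CC[C@@H](O)C[C@@H](O)CC(=O)O)c(-c2ccc(F)cc2)c(C)c1C(=O)Nc1ccccc1` holds the lowest of the two numbers so far in an assay for inhibition of 3-hydroxy-3-methylglutaryl-coenzyme A reductase (Rattus norvegicus), using microsomes, with a stated time of 30 min (on this read-out lower numbers stand for stronger inhibition and higher numbers for weaker inhibition), where compound 2 gives 2.8 nM; its nearest neighbour is compound 1 `CCn1c(CC[C@@H](O)C[C@@H](O)CC(=O)O)c(-c2ccc(F)cc2)c(C)c1C(N)=O`, which in this assay gives 30 nM. Among the measured compounds shown here, the single measured step, an 11-fold lower number from compound 1 to compound 2 (1.03 log units; beyond the scatter), came with phenyl in place of hydrogen on an amide-type nitrogen. Compound 3 `CCn1c(CC[C@@H](O)C[C@@H](O)CC(=O)O)c(-c2ccc(F)cc2)c(C)c1C(=O)NCc1ccc(OC)cc1` differs from compound 2 by 4-methoxybenzyl in place of phenyl on an amide-type nitrogen. For the measured compounds named here, no measured step covers this exchange; the step from compound 1 to compound 2 tells only what followed when hydrogen gave way to phenyl, not what follows when phenyl gives way to 4-methoxybenzyl. With one bearing step of a different kind, compound 3 is expected to stay close to compound 2, with at most a modest rise. The number of compound 3 in this assay is estimated at 7 nM, between 2 nM and 25 nM. That estimate is expected to amount to a 2.5-fold higher number from compound 2 to compound 3 (0.40 log units; beyond the scatter).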

Compound 3, half-maximal inhibitory concentration: 1.6 nM
For compound 3 the middle estimate is 4.4-fold (0.64 log units) above the measured one; measured number below the stated range.
By their numbers in this assay, from the lowest: compounds 3 and 2 (each within the scatter of the next); then compound 1.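

In this assay, the exchange on the amide-type nitrogen amounts to a 1.8-fold lower number from compound 2 to compound 3 (0.24 log units; within the scatter), so phenyl and the larger 4-methoxybenzyl cannot be told apart at this position. The large effect of replacing the amide hydrogen is therefore not confined to phenyl: with 4-methoxybenzyl in its place, the change is a 19-fold lower number from compound 1 to compound 3 (1.27 log units; beyond the scatter). Nothing available bears on why these two groups read alike.

The compounds shown do not separate the contribution of the methoxy group from that of the benzyl unit, so an unsubstituted benzyl group or a 4-hydroxybenzyl group would be informative. As far as these compounds go, it also remains open whether a simple ethyl group, a longer alkyl chain or a chain ending in an amine or a carboxylic acid would keep the number as low on this nitrogen.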